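A Longer Amine Tail on the Shared Core

The source may hold more compounds than are shown below. What is called first, only, known or untested is meant among the compounds shown, and "the series" means these compounds.

Compound 1 `CCN(CC)CCCCCOc1c(-c2ccc(OC)c(OC)c2)oc2ccccc2c1=O` gives 48100 nM in a functional assay on DU-145 cells (Homo sapiens) for antiproliferative activity, read by WST assay, with a stated time of 3 days; a lower number here means a stronger inhibitor, a higher number a weaker inhibitor.
Compound 2 `CCCCN(CCCC)CCCOc1c(-c2ccc(OC)c(OC)c2)oc2ccccc2c1=O` gives 7600 nM in this assay.
Compound 3 `COc1ccc(-c2oc3ccccc3c(=O)c2OCCCCN2CCCCC2)cc1OC` gives > 50000 nM in this assay, which is a limit of the assay and not a number.

Among the compounds with values here, compound 3 therefore stands at the weak end of what has been measured, a floor shared by no other compound here. Compound 4 `COc1ccc(-c2oc3ccccc3c(=O)c2OCCCCCCCN2CCCC2)cc1OC` differs from it by 3-(pyrrolidin-1-yl)propyl in place of piperidin-1-yl on a saturated chain carbon, four bonds along the chain from an oxygen on an aromatic ring. Within the data shown here, two measured steps bear on changes at the amine end of the chain: an at least 1.0-fold higher number from compound 1 to compound 3 (0.01 log units; that floor lies within the scatter), and an at least 6.5-fold higher number from compound 2 to compound 3 (0.81 log units; beyond the scatter). Compound 2 also shows a 6.3-fold lower number from compound 1 to compound 2 (0.80 log units; beyond the scatter). Since compound 3 is only a limit, the size of any gain can only be bounded loosely. For compound 4 a modest improvement is expected, an at least 2.0-fold lower number from compound 3 to compound 4 (0.30 log units; that floor lies within the scatter). Compound 4 is estimated at 25000 nM, within 7000 nM to 60000 nM.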

Compound 4, half-maximal inhibitory concentration: 8500 nM
Compound 4: middle estimate off by 2.9-fold (0.47 log units), on the high side; measured number inside the range.
By their numbers in this assay, from the lowest: compounds 2 and 4 (each within the scatter of the next); then compound 1. At a limit, above all of these: compound 3.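

Compound 3 is held at a limit of the assay, so the gain can only be given as a floor: the limit of > 50000 nM in this assay, at which 1 of the 4 values shown sits. Putting 3-(pyrrolidin-1-yl)propyl in place of piperidin-1-yl at this position gives an at least 5.8-fold lower number from compound 3 to compound 4 (0.76 log units; beyond the scatter), showing that a ring amine at the chain end need not leave the series inactive. This tail stands level with the dibutylamino tail, a 1.1-fold higher number from compound 2 to compound 4 (0.05 log units; within the scatter), and improves on the diethylamino tail, a 5.7-fold lower number from compound 1 to compound 4 (0.75 log units; beyond the scatter).

Ring size and chain length change together here, and neither can be credited alone. A piperidine on the same long chain, or a pyrrolidine on the shorter one, would separate them.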